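This account rests on a few compounds, and the source may have more. Where it says the series, first, only, none or still open, it means among the compounds named here.

Measured compounds:
- compound 1 `N#Cc1cccc(/C=N/NC(=O)c2ccc(O[C@@H]3O[C@H](CO)[C@@H](O)[C@H](O)[C@H]3O)cc2)c1`: 6.17%
- compound 2 `CC(=O)OC[C@H]1O[C@@H](Oc2ccc(-c3nnc(-c4ccc([N+](=O)[O-])cc4)o3)cc2)[C@H](OC(C)=O)[C@@H](OC(C)=O)[C@@H]1OC(C)=O`: 58%

In a functional assay on MDA-MB-231 cells (Homo sapiens) for inhibition, read by MTT assay, with a stated time of 24 h, tested at 100 uM (a lower number here means less inhibition, a higher number more inhibition at the concentration tested (going by the name of the read-out)), compound 1 gives the lower of the two numbers, and compound 2 gives 58%, a value well beyond the scatter above it. Compound 3 `CC(C)/C=N/NC(=O)c1ccc(O[C@@H]2O[C@H](CO)[C@@H](O)[C@H](O)[C@H]2O)cc1` is not yet measured. It differs from compound 1 in one place: isopropyl in place of 3-cyanophenyl on a carbon with a double bond to nitrogen. Going by the values given here, no measured pair shows the effect of such a change, so the expectation rests on compound 1 alone, whose 6.17% is close to no inhibition. The step of a number 0.2 percentage points lower from compound 1 to compound 3 (within the scatter) is expected to stay within the usual scatter. Compound 3 is therefore estimated at 6%, with a range from 0% to 20%.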

Compound 3, a percentage reported as inhibition, at one concentration (the size of the read-out at that concentration, not a potency): 1.7%
Beside the measured number, compound 3's estimate is 4.3 percentage points above it; low and high end bracket the measured number.
By their numbers in this assay, from the lowest: compounds 3 and 1 (each within the scatter of the next); then compound 2.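

In this assay the exchange of 3-cyanophenyl for isopropyl gives a number 4.5 percentage points lower from compound 1 to compound 3 (within the scatter) and so removes an aromatic ring and a nitrile with no readable effect on the number. Both compounds stay close to no inhibition, so neither group at this position gives a clear effect, and any real difference between them could go unseen this near the bottom of the scale. Nothing measured here offers an explanation for this result.

On these data alone, whether an amine, a carboxylic acid or a longer chain on this carbon would bring inhibition clear of that low level remains open.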